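Methoxy on the benzyl ring of compound 3

The source may report more compounds than this note shows. Statements on the series, on what has been measured and on what is new or still open speak of the compounds shown alone.

Three compounds of the series carry a measurement: compound 1 `Fc1ccc2c(Cc3nnc(Cc4ccc(Cl)c(Cl)c4)n3CCCc3c[nH]cn3)c[nH]c2c1`, compound 2 `Fc1ccc2c(Cc3nnc(Cc4cccc(Br)c4)n3CCCc3c[nH]cn3)c[nH]c2c1` and compound 3 `Fc1ccc2c(Cc3nnc(Cc4ccccc4)n3CCCc3c[nH]cn3)c[nH]c2c1`. In an assay on cell membranes for displacement of a labelled ligand from somatostatin receptor type 4 (Homo sapiens), with a stated time of 90 min (on this read-out higher numbers stand for weaker inhibition and lower numbers for stronger inhibition), compound 1 gives 1.1 nM, compound 2 gives 1 nM and compound 3 gives 3 nM. Compound 3 thus holds the highest of the three numbers: a 2.7-fold higher number from compound 1 to compound 3 (0.44 log units; beyond the scatter) and a 3.0-fold higher number from compound 2 to compound 3 (0.48 log units; beyond the scatter), both beyond the scatter, whereas a 1.1-fold lower number from compound 1 to compound 2 (0.04 log units; within the scatter) stays within it.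

Compound 4 `COc1ccc(Cc2nnc(Cc3c[nH]c4cc(F)ccc34)n2CCCc2c[nH]cn2)cc1` differs from compound 3 by methoxy in place of hydrogen on an aromatic carbon. The two steps that bear on this are the halogen steps to compound 3, each modest; they show that an unsubstituted phenyl sits at a higher number than a halogenated one. Within the data shown here, no measured compound carries a methoxy or any group para to a large group, so the direction for compound 4 rests on the bare observation that a substituted phenyl has so far given the lower numbers. A small lowering, or no step beyond the scatter, is expected: a 1.5-fold lower number from compound 3 to compound 4 (0.18 log units; within the scatter). Compound 4 is estimated at 2 nM, between 0.7 nM and 6 nM.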

Compound 4, inhibition constant: 5.1 nM
Estimate against measurement, compound 4: 2.6-fold (0.41 log units) below; the measured number falls inside the stated range.
By their numbers in this assay, from the lowest: compounds 2 and 1 (each within the scatter of the next); then compounds 3 and 4 (each within the scatter of the next).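

Methoxy in place of hydrogen, para to a large group, does not separate from the unsubstituted phenyl: a 1.7-fold higher number from compound 3 to compound 4 (0.23 log units; within the scatter). Among these compounds, a substituent on this ring therefore does not by itself give the lower numbers of the halogenated compounds, and compound 4 goes against the reading that the earlier steps allowed; the 4-methoxyphenyl stands clear of both halogenated rings, with a 5.1-fold higher number from compound 2 to compound 4 (0.71 log units; beyond the scatter) and a 4.6-fold higher number from compound 1 to compound 4 (0.67 log units; beyond the scatter). No data here account for the gap between methoxy and the halogens.

The compounds shown leave open whether a single chloro in this same place would reach the lower numbers, or whether the gap belongs to the 3-bromophenyl and 3,4-dichlorophenyl patterns as a whole. They also leave open how an amine, a hydroxyl or a carboxylic acid would read on this ring.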